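The compounds below may be only part of what the source reports. "The series", "measured", "known", "first", "only" and "open" are said of these compounds alone.

Compound 1 `O=C1NC(=S)/C(=C/c2ccc(Cl)cc2)S1` gives 16.1%
Compound 2 `O=C1NC(=S)/C(=C/c2ccccc2Cl)S1` gives 5.97%

Within the data shown here, in a functional assay on HEp-2 cells (Homo sapiens) for cytotoxicity, read by MTT assay, with a stated time of 72 h, tested at 5 ug/mL (on this read-out higher numbers stand for more inhibition of growth at the one concentration tested and lower numbers for less inhibition of growth), compound 2 stands lowest of the two numbers measured so far. Its nearest neighbour is compound 1, whose number lies higher by a gap beyond the usual scatter. Compound 3 `O=C1NC(=S)/C(=C/c2ccc(Cl)cc2Cl)S1` is not yet measured. It differs from compound 2 by one change: chloro in place of hydrogen on an aromatic carbon. Among the measured compounds shown here, no step between two measured compounds is available, so the size of this step cannot be read off a matched pair. For the measured compounds named here, the only hint comes from compound 1, which also carries a single chloro group on its ring and gives 16.1% in this assay. Compound 3 is therefore expected to gain a little, a step of a number 8 percentage points higher from compound 2 to compound 3 (within the scatter), though the rise may stay within the scatter. The estimate for compound 3 is 14%, with a range from 3% to 30%.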

Compound 3, percent growth inhibition at one concentration: 20%
Estimate against measurement, compound 3: 6 percentage points below; the measured number falls inside the stated range.
By their numbers in this assay, from the lowest: compound 2; then compounds 1 and 3 (each within the scatter of the next).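

In this assay the first matched pairs are now available, and chloro in place of hydrogen on the aromatic carbon meta to a chloro group and para to a group of 8 heavy atoms gives a number 14 percentage points higher from compound 2 to compound 3 (beyond the scatter). The same kind of change, reached instead from the other compound with a single chloro on its ring, gives a number 3.9 percentage points higher from compound 1 to compound 3 (within the scatter), so a second chloro makes a clear difference in one pair and none that can be separated from the scatter in the other. Nothing measured here explains why these two steps part ways.

From the compounds shown here alone, whether a methoxy group or an amine on the same aromatic carbon would match chloro remains open. So does the effect of a carboxylic acid there.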